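The source may hold more compounds than are shown below. What is called first, only, known or untested is meant among the compounds shown, and "the series" means these compounds.

Measured in an ADME assay on MT4 cells (Homo sapiens) for cytotoxicity, read by MTT assay; on this read-out lower numbers stand for higher toxicity in this test and higher numbers for lower toxicity in this test:
- compound 1 `O=C1c2ccccc2C(=O)N1CCOC(=S)N(C(=O)c1ccc(Cl)cc1Cl)c1ccc(Cl)cc1`: 18000 nM
- compound 2 `Cc1ccc(N(C(=O)c2ccc(F)cc2F)C(=S)OCCN2C(=O)c3ccccc3C2=O)cc1`: 20000 nM
- compound 3 `Cc1ccc(N(C(=O)c2cc(F)ccc2F)C(=S)OCCN2C(=O)c3ccccc3C2=O)cc1`: 62000 nM

Of these three, compound 3 stands highest at 62000 nM. Compound 4 `Cc1ccc(N(C(=O)c2ccc(Cl)cc2Cl)C(=S)OCCN2C(=O)c3ccccc3C2=O)cc1` is still unmeasured and differs from compound 3 in one group: 2,4-dichlorophenyl in place of 2,5-difluorophenyl on a carbonyl carbon. For the measured compounds named here, the one measured step that bears on this is modest: a 3.1-fold higher number from compound 2 to compound 3 (0.49 log units; beyond the scatter), which came with 2,5-difluorophenyl in place of 2,4-difluorophenyl on a carbonyl carbon. Compound 4 gives up that 2,5-difluorophenyl, so a return to a lower number is expected in this assay. Compound 1, which also carries 2,4-dichlorophenyl but differs elsewhere, gives 18000 nM. The expected change is a 3.1-fold lower number from compound 3 to compound 4 (0.49 log units; beyond the scatter). For compound 4 the estimate is 20000 nM, with an expected range from 9000 nM to 42000 nM.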

Compound 4, half-maximal cytotoxic concentration: 49000 nM
The estimate for compound 4 lay 2.5-fold (0.39 log units) below the measured number; measured number outside the range, above it.
By their numbers in this assay, from the lowest: compounds 1 and 2 (each within the scatter of the next); then compounds 4 and 3 (each within the scatter of the next).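

In this assay, the number at this carbonyl position is not tied to 2,5-difluorophenyl: 2,4-dichlorophenyl gives a 1.3-fold lower number from compound 3 to compound 4 (0.10 log units; within the scatter), and, in place of 2,4-difluorophenyl, a 2.5-fold higher number from compound 2 to compound 4 (0.39 log units; beyond the scatter). With 2,4-dichlorophenyl held fixed, methyl in place of chloro on the aromatic carbon gives a 2.7-fold higher number from compound 1 to compound 4 (0.43 log units; beyond the scatter), so that second place also shifts the number. Nothing available accounts for these shifts. Going by these compounds, it remains open how a plain phenyl or a 2,4-dimethoxyphenyl on the carbonyl carbon would read, or a methoxy group in place of that methyl.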